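This account rests on a few compounds, and the source may have more. Where it says the series, first, only, none or still open, it means among the compounds named here.

Measured so far:
compound 1 `COC(=O)c1cccc(-c2cnc(C(=O)CCCCCCc3ccccc3)o2)c1` — 12 nM
compound 2 `NC(=O)c1ccc(-c2cnc(C(=O)CCCCCCc3ccccc3)o2)cc1` — 10 nM

In an assay (Rattus norvegicus) for inhibition of Fatty-acid amide hydrolase 1 (Homo sapiens) (on this read-out higher numbers stand for weaker inhibition and lower numbers for stronger inhibition), compound 2 gives the lowest of the two numbers, and compound 1 sits so close that the two values are within the scatter; the data allow no ordering between them. Compound 3 `O=C(CCCCCCc1ccccc1)c1ncc(I)o1` has not yet been measured in this assay. It differs from compound 2 by iodo in place of 4-carbamoylphenyl on an aromatic carbon. For the measured compounds named here, no step between two measured compounds covers a change of this kind, so there is no measured guide to its size. Both measured compounds carry a substituted phenyl ring at this position and both give low numbers; with only a single halogen left there, the number for compound 3 is expected to move upward, by a step estimated as a 10-fold higher number from compound 2 to compound 3 (1.00 log units; beyond the scatter), beyond the scatter. Compound 3 is therefore estimated to give 100 nM in this assay, within a range from 20 nM to 600 nM.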

Compound 3, inhibition constant: 3 nM
For compound 3 the middle estimate is 33-fold (1.52 log units) above the measured one; the whole stated range lies above it.
By their numbers in this assay, from the lowest: compound 3; then compounds 2 and 1 (each within the scatter of the next).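

In this assay, the position next to the ring oxygen does not depend on the 4-carbamoylphenyl group: exchanging that group, with its six-membered aromatic ring and its hydrogen-bond donor and acceptor, for a single iodo atom gives a 3.3-fold lower number from compound 2 to compound 3 (0.52 log units; beyond the scatter), a modest step. A low number at this position therefore needs neither that ring nor that donor and acceptor, and a lone halogen on the shared core gives a lower number than this larger group does. Nothing available here accounts for the direction of this step.

The compounds shown leave open whether the lower number belongs to iodine itself or simply follows from removing the substituted phenyl ring. Bromo, chloro or plain hydrogen at this position would separate these two readings, and an amine or a carboxylic acid there remains an open case.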